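Methylamino in place of methoxy: an expected step

This account rests on a few compounds, and the source may have more. Where it says the series, first, only, none or still open, it means among the compounds named here.

Compound 1 `CCOc1cc(C(=O)Nc2nn[nH]n2)nc(-c2ccc(N)cc2)c1`: 19%
Compound 2 `COc1ccc(-c2cccc(C(=O)Nc3nn[nH]n3)n2)cc1`: 4%

Of the compounds shown here, two have been measured in a functional assay on the whole organism for inhibition, with Rattus norvegicus as the target, at a dose of 0.3 mg/kg by the oral route; a higher number here means a stronger effect of the compound at the dose given, a lower number a weaker effect. Compound 1 gives 19% in this assay, while compound 2 gives 4%, the lower of the two numbers, and the gap between them is beyond the usual scatter. Within the data shown here, the two structures differ in more than one place, so no single step can be drawn between them; their two values simply show where each stands.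

Compound 3 `CNc1ccc(-c2cccc(C(=O)Nc3nn[nH]n3)n2)cc1` is not yet measured. It differs from compound 2 in one place: methylamino in place of methoxy on an aromatic carbon. Among the measured compounds shown here, no measured pair shows this change, so its size is open. A modest rise is expected for compound 3, with the step of a number 8 percentage points higher from compound 2 to compound 3 (within the scatter) expected to stay at or near the edge of the scatter. Compound 3 is estimated at 12%, within a range from 0% to 30%.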

Compound 3, a percentage reported as inhibition, in the whole organism at one dose (the size of the read-out at that dose, not a potency): 29%
The estimate for compound 3 lay 17 percentage points below the measured number; measured number inside the range.
By their numbers in this assay, from the lowest: compound 2; then compounds 1 and 3 (each within the scatter of the next).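

In this assay, methylamino in place of methoxy, on an aromatic carbon para to a large group, gives a number 25 percentage points higher from compound 2 to compound 3 (beyond the scatter). This is the first change in one place among these compounds, and it shows that the read-out at this dose responds to what is attached at this position, even though the group keeps its size of 2 heavy atoms and exchanges only oxygen for nitrogen, gaining a hydrogen-bond donor. Nothing available here accounts for the rise.

The compounds shown leave open whether the step follows the hydrogen on the nitrogen or the nitrogen itself, which dimethylamino at the same position would help to separate. They also leave open how far the rise extends to a longer chain on the nitrogen, such as ethylamino.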